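Methyl for Trifluoromethyl: Expected Rat Clearance of Compound 4

The compounds below may be only part of what the source reports. "The series", "measured", "known", "first", "only" and "open" are said of these compounds alone.

Of the compounds shown here, three sharing a common core have been tested in an ADME assay on the whole organism for pharmacokinetics, with Rattus norvegicus as the target, at a dose of 3 mg/kg by the intravenous route; on this read-out lower numbers stand for slow clearance and higher numbers for fast clearance. Compound 1 `NC(=O)CN1CCC[C@H](Nc2nc(-c3c[nH]c4ncc(Cl)cc34)ncc2F)C1` gives 182 mL/min/kg in this assay. Compound 2 `O=C(O)[C@H]1CCCC[C@@H]1Nc1nc(-c2c[nH]c3ncc(Cl)cc23)ncc1F` gives 16 mL/min/kg in this assay. Compound 3 `O=C(N[C@@H]1CCC[C@H](Nc2nc(-c3c[nH]c4ncc(C(F)(F)F)cc34)ncc2F)C1)N1CCOCC1` gives 81 mL/min/kg in this assay, which places it second highest of the three numbers: compound 1 stands higher, beyond the usual scatter, and compound 2 stands lower, also beyond the scatter.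

Compound 4 `Cc1cnc2[nH]cc(-c3ncc(F)c(N[C@H]4CCC[C@@H](NC(=O)N5CCOCC5)C4)n3)c2c1` has not yet been measured in this assay. It differs from compound 3 in a single place: methyl in place of trifluoromethyl on an aromatic carbon. Everything else in the molecule is kept.

Among the measured compounds shown here, no pair of compounds measured so far isolates this exact change, so the expectation rests on compound 3 alone and on the small size of the swap. The step from compound 3 to compound 4 in this assay is expected to be a 1.0-fold lower number from compound 3 to compound 4 (0.01 log units; within the scatter), which is not beyond the scatter in either direction. Compound 4 is therefore estimated to give 80 mL/min/kg in this assay, within a range from 40 mL/min/kg to 160 mL/min/kg.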

Compound 4, clearance: 78 mL/min/kg
Compound 4: the middle estimate sits 1.0-fold (0.01 log units) above what was measured; the measured number falls inside the stated range.
By their numbers in this assay, from the lowest: compound 2; then compounds 4 and 3 (each within the scatter of the next); then compound 1.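

In this assay, methyl in place of trifluoromethyl on an aromatic carbon gives a 1.0-fold lower number from compound 3 to compound 4 (0.02 log units; within the scatter). This is the first pair shown that differs in one place, and it indicates that, with the rest of compound 3 kept, clearance in rat does not distinguish these two groups at this position. Nothing measured here explains why the two groups read alike.

From the compounds shown here alone, the result comes from a single pair, so it is open whether the same holds when the rest of the molecule is different, as in the side chains of compound 1 and compound 2. Going by these compounds, it is also open how clearance responds at this position to other groups, such as a nitrile, a methoxy group or a longer alkyl chain.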